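The compounds below may be only part of what the source reports. "The series", "measured", "known", "first", "only" and "open" are said of these compounds alone.

Measured in a functional assay on A549 cells (Homo sapiens) for antiproliferative activity, read by MTT assay, with a stated time of 48 h; on this read-out lower numbers stand for stronger inhibition and higher numbers for weaker inhibition:
compound 1 `COc1ccc(C(=O)c2ccc(OC)c3c2OC(C)(C)C=C3)c(NC(=O)CO)c1`: 80 nM
compound 2 `COc1ccc(C(=O)c2ccc(OC)c3c2C=CC(C)(C)O3)c(NC(=O)CN)c1`: 420 nM
compound 3 `COc1ccc(C(=O)c2ccc3c(c2)C=CC(C)(C)O3)c(NC(=O)CN)c1`: 310 nM

Compound 1 holds the lowest number of the three, and its gaps to compound 3 and to compound 2 both lie beyond the scatter. Compound 4 `CNCC(=O)Nc1cc(OC)ccc1C(=O)c1ccc(OC)c2c1OC(C)(C)C=C2` keeps the core of compound 1 and carries methylamino in place of hydroxy on a saturated chain carbon bound to a carbonyl carbon. Among the measured compounds shown here, no single-place step among the measured compounds isolates this change. The nearest evidence is indirect: compound 2 at 420 nM and compound 3 at 310 nM also carry nitrogen on that chain carbon, but their cores differ from that of compound 1, so they support the direction only loosely. A moderate move towards weaker inhibition in this assay is expected, estimated as a 2.8-fold higher number from compound 1 to compound 4 (0.44 log units; beyond the scatter). For compound 4 the estimated value is 220 nM, with an expected range of 70 nM to 650 nM.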

Compound 4, half-maximal inhibitory concentration: 620 nM
Estimate against measurement, compound 4: 2.8-fold (0.45 log units) below; the range from low to high includes it.
By their numbers in this assay, from the lowest: compound 1; then compounds 3, 2 and 4 (each within the scatter of the next).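

In this assay, among the compounds shown here, the change from hydroxy to methylamino on a saturated chain carbon bound to a carbonyl carbon gives a 7.8-fold higher number from compound 1 to compound 4 (0.89 log units; beyond the scatter) and is the first direct reading of this position on the core of compound 1. The position is thus sensitive to the group it carries: the step lies beyond the scatter, although the count of hydrogen-bond donors and acceptors is the same for both groups. Nothing at hand accounts for the size of this step, so it stands as an observation only.

The compounds shown cannot separate the effect of the nitrogen from that of its methyl, as the core of compound 1 appears here with neither a primary amine nor a dimethylamino group at this place. Also open, on these data alone, is how a methoxy group or a longer chain bearing hydroxy would read at this position.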